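The source may report more compounds than this note shows. Statements on the series, on what has been measured and on what is new or still open speak of the compounds shown alone.

Measured compounds:
Compound 1, `COc1ccc(Cn2c(NCCNC(=N)N)nc(=O)n(Cc3ccc(Br)cc3)c2=O)cc1`: 0.00036 nM
Compound 2, `COc1ccc(Cn2c(=O)nc(NCCNC(=N)N)n(Cc3ccc(Cl)cc3)c2=O)cc1`: 0.0044 nM

Both were tested in a functional assay on the whole organism (strain C57Bl/6) for inhibition, with Mus musculus as the target, with a stated time of 180 min, at 48 degrees C; a lower number here means that less compound is needed, a higher number that more compound is needed for the effect. Compound 1 gives 0.00036 nM, and compound 2 gives 0.0044 nM. Of these two numbers, compound 2 holds the higher one, and its gap to compound 1 lies beyond the usual scatter of repeated measurements. The two compounds differ in more than one place, so only what their two values show is noted here.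

Compound 3, `COc1ccc(Cn2c(=O)nc(NCCNC(=N)N)n(Cc3ccc(Cl)c(Cl)c3)c2=O)cc1`, has not yet been measured in this assay. It differs from compound 2 in a single place: chloro in place of hydrogen on an aromatic carbon. Among the compounds with values here, no pair of measured compounds shows this change, so there is no measured step to lean on. The expected step is a 1.1-fold lower number from compound 2 to compound 3 (0.04 log units; within the scatter), small and in no sure direction, or none beyond the scatter. Compound 3 is therefore estimated at 0.004 nM, with a range from 0.001 nM to 0.02 nM.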

Compound 3, half-maximal effective concentration: 0.0045 nM
The estimate for compound 3 lay 1.1-fold (0.05 log units) below the measured number; low and high end bracket the measured number.
By their numbers in this assay, from the lowest: compound 1; then compounds 2 and 3 (each within the scatter of the next).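

In this assay there is a 1.0-fold higher number from compound 2 to compound 3 (0.01 log units; within the scatter) on placing chloro where hydrogen stood, which turns the 4-chlorobenzyl group into 3,4-dichlorobenzyl. Within the data shown here, this is the first comparison that isolates a single place, and it shows that at this position, ortho to a chloro group on the aromatic ring, the added chloro leaves compound 2 and compound 3 within the scatter of each other. No measurement at hand offers an explanation for this result.

On these data alone, whether an amine, a carboxylic acid or a longer chain at this same position would also stay within the scatter of compound 2 remains open. Also open is which of the several differences between compound 1 and compound 2 accounts for the gap in their values.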